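Phenyl on the piperazine nitrogen of a benzodiazepine-type amide

The source may hold more compounds than are shown below. What is called first, only, known or untested is meant among the compounds shown, and "the series" means these compounds.

Compound 1 `CN1CCN(CC(=O)NCC(=O)N(C)c2ccc(Cl)cc2C(=O)c2ccccc2Cl)CC1`: 59 mg/kg
Compound 2 `CN(C(=O)CNC(=O)c1ccccc1)c1ccc(Cl)cc1C(=O)c1ccccc1Cl`: 2.9 mg/kg

In a functional assay on the whole organism for antagonist activity, with Mus musculus as the target (a lower number here means that less compound is needed, a higher number that more compound is needed for the effect), compound 1 gives the higher of the two numbers; the nearest is a 20-fold lower number from compound 1 to compound 2 (1.31 log units; beyond the scatter). Compound 3 `CN(C(=O)CNC(=O)CN1CCN(c2ccccc2)CC1)c1ccc(Cl)cc1C(=O)c1ccccc1Cl` keeps the shared core of compound 1 and changes only the piperazine end: phenyl in place of methyl on an amine nitrogen in a ring. Among the compounds with values here, the one measured step does not cover this change, since it removes the whole (4-methylpiperazin-1-yl)methyl group rather than enlarging it, so it bears on compound 3 only loosely. A modest downward step is expected, a 2.4-fold lower number from compound 1 to compound 3 (0.37 log units; beyond the scatter). Compound 3 is therefore estimated at 25 mg/kg, with a range from 8 mg/kg to 80 mg/kg.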

Compound 3, dose for half-maximal effect: 75 mg/kg
Compound 3: middle estimate off by 3.0-fold (0.48 log units), on the low side, within the range that was stated.
By their numbers in this assay, from the lowest: compound 2; then compounds 1 and 3 (each within the scatter of the next).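

Phenyl in place of methyl on the amine nitrogen in the ring gives a 1.3-fold higher number from compound 1 to compound 3 (0.10 log units; within the scatter) in this assay and so leaves the two compounds indistinguishable. The earlier step removed the whole (4-methylpiperazin-1-yl)methyl group, whereas here six heavy atoms replace one at the far end of the piperazine and the numbers stay within the scatter. Nothing at hand explains this result.

Open, going by these compounds, is whether a benzyl or acetyl group on this nitrogen would behave likewise. Also open, on these data alone, is whether morpholine or dimethylamine in place of the whole piperazine would move the number.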